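Adding an Ethylcarbamoyl Group to a Weak Biphenyl Ether

This account rests on a few compounds, and the source may have more. Where it says the series, first, only, none or still open, it means among the compounds named here.

Of the compounds shown here, three have been measured in an assay on COS-7 cells for inhibition of patatin-like phospholipase domain-containing protein 2 (Mus musculus); on this read-out higher numbers stand for weaker inhibition and lower numbers for stronger inhibition. Compound 1, `CCOC(=O)c1cccc(-c2ccc(OCC)cc2)n1`, gives 60000 nM. Compound 2, `CCOC(=O)C1CCCC(c2ccc(OCC)cc2)N1`, reaches only the limit of the assay, > 200000 nM. Compound 3, `CCOc1ccc(-c2ccccc2)cc1`, likewise reaches only the limit of the assay, > 200000 nM. On the numbers shown, compound 3 thus stands at the weak end, where no number but only a limit is known; (the limit of > 200000 nM in this assay, at which 2 of the 3 values shown sit). Within the data shown here, no two measured compounds differ in just one place, so no single measured step is available.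

Compound 4, `CCNC(=O)c1cccc(-c2ccc(OCC)cc2)c1`, is built from compound 3 by one change: ethylcarbamoyl in place of hydrogen on an aromatic carbon. This brings compound 4 closer in make-up to compound 1, which also carries a carbonyl group and gives 60000 nM in this assay. A gain in inhibition beyond the scatter is expected for compound 4, an at least 2.5-fold lower number from compound 3 to compound 4 (0.39 log units; beyond the scatter), although the starting point is only a limit. Compound 4 is estimated to give about 80000 nM, with a likely range from 20000 nM to 300000 nM.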

Compound 4, half-maximal inhibitory concentration: 90000 nM
Compound 4: middle estimate off by 1.1-fold (0.05 log units), on the low side; the range from low to high includes it.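

Putting ethylcarbamoyl in place of hydrogen on an aromatic carbon, meta to a group of 9 heavy atoms, gives an at least 2.2-fold lower number from compound 3 to compound 4 (0.34 log units; beyond the scatter). This lifts the compound off the weak end of this assay and onto a measured number, so this position on the ring can carry a group of this size and still give a readable value, although inhibition stays weak. Compound 3 has only a limit, so the full size of this gain cannot be read: the limit of > 200000 nM in this assay, at which 2 of the 4 values shown sit.

With only ethylcarbamoyl shown at this place, it remains open whether a carboxylic acid, a primary amine or a longer chain on the amide nitrogen would give stronger or weaker inhibition. As far as these compounds go, it is also open whether ethylcarbamoyl would give a similar gain on another carbon of that ring.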